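A few compounds are considered here, and "the series" means these few. Any claim that something is new, unique, unknown or untested is made for them only; others in the source may bear on it.

Compound 1 `Cc1cc(C#N)cc(C)c1Oc1ccnc(S(=O)(=O)CC(=O)Nc2ccccc2F)n1` — in an ADME assay on MT4 cells (Homo sapiens) for cytotoxicity, read by MTT assay, with a stated time of 4 days (on this read-out lower numbers stand for higher toxicity in this test and higher numbers for lower toxicity in this test), compound 1 gives 28400 nM.
Compound 2 `Cc1cc(C#N)cc(C)c1Oc1ccnc(S(=O)(=O)CC(=O)Nc2ccc(Cl)cc2)n1` — in this assay compound 2 gives 16600 nM.
Compound 3 `Cc1cc(C#N)cc(C)c1Oc1ccnc(S(=O)(=O)CC(=O)Nc2cc(Cl)cc(Cl)c2)n1` — in this assay compound 3 gives 24000 nM.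

Compound 3 stands second highest of the three numbers; its nearest neighbour is compound 1, as shown by a 1.2-fold lower number from compound 1 to compound 3 (0.07 log units; within the scatter), and a 1.4-fold higher number from compound 2 to compound 3 (0.16 log units; within the scatter) is also within the scatter. Compound 4 `Cc1cc(C#N)cc(C)c1Oc1ccnc(S(=O)(=O)CC(=O)Nc2cccc([N+](=O)[O-])c2)n1` differs from compound 3 by 3-nitrophenyl in place of 3,5-dichlorophenyl on an amide-type nitrogen. Within the data shown here, none of the measured steps involves a nitro group; they exchange only chlorine and fluorine substituents on the phenyl held by the amide-type nitrogen, and a 1.7-fold lower number from compound 1 to compound 2 (0.23 log units; within the scatter), a 1.2-fold lower number from compound 1 to compound 3 (0.07 log units; within the scatter) and a 1.4-fold higher number from compound 2 to compound 3 (0.16 log units; within the scatter) all remain within the scatter. No step beyond the scatter is therefore expected in this assay for compound 4. Compound 4 is estimated at 22000 nM, with a range from 10000 nM to 45000 nM, the expected step being a 1.1-fold lower number from compound 3 to compound 4 (0.04 log units; within the scatter).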

Compound 4, half-maximal cytotoxic concentration: 23600 nM
Compound 4: the middle estimate sits 1.1-fold (0.03 log units) below what was measured; low and high end bracket the measured number.
By their numbers in this assay, from the lowest: compounds 2, 4, 3 and 1 (each within the scatter of the next).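

In this assay the change to 3-nitrophenyl on an amide-type nitrogen gives a 1.0-fold lower number from compound 3 to compound 4 (0.01 log units; within the scatter) and a 1.4-fold higher number from compound 2 to compound 4 (0.15 log units; within the scatter) and a 1.2-fold lower number from compound 1 to compound 4 (0.08 log units; within the scatter) at this position. The tolerance seen so far among chlorine and fluorine substituents therefore extends to a group with nitrogen and oxygen atoms, which counts 2 hydrogen-bond acceptors where 3,5-dichlorophenyl counts 0. Nothing available explains this flat result. Still open, from the compounds shown here alone, is whether a phenyl carrying an amine or a carboxylic acid would stay within the scatter. Going by these compounds, a longer chain on this nitrogen in place of the phenyl is equally open.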